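A few compounds are considered here, and "the series" means these few. Any claim that something is new, unique, unknown or untested is made for them only; others in the source may bear on it.

Compound 1 `COc1ccc(NC(=S)Nc2nc(C(=O)NCCCc3ccccc3)cs2)cc1` gives 74500 nM
Compound 2 `CCOC(=O)c1csc2nc(CN3CCN(C)CC3)c(-c3ccc(C)cc3)n12` gives 65000 nM
Compound 3 `CCOC(=O)c1csc2nc(CN3CCN(Cc4ccccc4)CC3)c(-c3ccc(C)cc3)n12` gives > 100000 nM (a limit of the assay)

In a functional assay on PC-3 cells (Homo sapiens) for antiproliferative activity, read by MTT assay, with a stated time of 72 h (on this read-out higher numbers stand for weaker inhibition and lower numbers for stronger inhibition), compound 2 gives 65000 nM and lies within the scatter of compound 1 at 74500 nM. Compound 4 `CCOC(=O)c1csc2nc(CN3CCN(C)CC3)c(-c3ccc(Br)cc3)n12` differs from compound 2 in one place: bromo in place of methyl on an aromatic carbon. Among the compounds with values here, the one measured step, an at least 1.5-fold higher number from compound 2 to compound 3 (0.18 log units; that floor lies within the scatter), changes another part of the structure, and its floor lies within the scatter. It therefore gives no reason to expect a change beyond the scatter here, in either direction. The expected step is a 1.2-fold lower number from compound 2 to compound 4 (0.07 log units; within the scatter). For compound 4 the estimated value is 55000 nM, with an expected range from 20000 nM to 100000 nM.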

Compound 4, half-maximal inhibitory concentration: 85000 nM
Estimate against measurement, compound 4: 1.5-fold (0.19 log units) below; low and high end bracket the measured number.
By their numbers in this assay, from the lowest: compounds 2, 1 and 4 (each within the scatter of the next). At a limit, above all of these: compound 3.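

Replacing 4-methylphenyl with 4-bromophenyl is the first change shown at this aromatic carbon. In this assay it gives a 1.3-fold higher number from compound 2 to compound 4 (0.12 log units; within the scatter), so the swap of methyl for bromo moves the number no further than repeated measurements would. The top of the measurable range also bounds these readings: the limit of > 100000 nM in this assay, at which 1 of the 4 values shown sits. As far as these compounds go, it remains open whether an amine or a carboxylic acid at this place would bring a number clearly lower than that of compound 2.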